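A few compounds are considered here, and "the series" means these few. Any claim that something is new, unique, unknown or untested is made for them only; others in the source may bear on it.

The measured compounds:
Compound 1 `N#Cc1ccn2c(-c3ccccc3)c(-c3ccccc3)c(OCOCc3ccccc3)c2c1` gives 39000 nM in an assay for inhibition of Polyunsaturated fatty acid lipoxygenase ALOX15 (Oryctolagus cuniculus); a higher number here means a weaker inhibitor, a lower number a stronger inhibitor.
Compound 2 `N#Cc1ccn2c(-c3ccccc3)c(-c3ccccc3)c(OCc3ccc(Cl)cc3)c2c1` has "not determined" (no result reported) in this assay.
Compound 3 `COc1ccccc1COc1c(-c2ccccc2)c(-c2ccccc2)n2ccc(C#N)cc12` has "not determined" (no result reported) in this assay.

Going by the values given here, compound 1 thus stands as the only entry with a number; compounds 2 and 3 report no value, so no step between measured compounds can be drawn. Compound 4 `N#Cc1ccn2c(-c3ccccc3)c(-c3ccccc3)c(CO)c2c1` differs from compound 1 in one place: hydroxymethyl in place of (benzyloxy)methoxy on an aromatic carbon. Among the compounds with values here, with no measured step to lean on, the expected change is uncertain; compound 1 is already a weak inhibitor, and the estimated step is a 1.3-fold higher number from compound 1 to compound 4 (0.11 log units; within the scatter), a modest move toward a weaker inhibitor that may well fall within the scatter. Compound 4 is expected to give 50000 nM, with a range from 15000 nM to 200000 nM.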

Compound 4, half-maximal inhibitory concentration: 34000 nM
The estimate for compound 4 lay 1.5-fold (0.17 log units) above the measured number; the measured number falls inside the stated range.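

In this assay, hydroxymethyl in place of (benzyloxy)methoxy on this aromatic carbon gives a 1.1-fold lower number from compound 1 to compound 4 (0.06 log units; within the scatter), so the two compounds cannot be told apart. At this position, then, the group can lose its six-membered aromatic ring of carbon only and most of its heavy atoms without a change in the number that lies beyond the scatter. Nothing available explains this result. The compounds shown leave open whether an amine or a carboxylic acid on this carbon would move the number beyond the scatter.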